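The source may hold more compounds than are shown below. What is called first, only, known or untested is meant among the compounds shown, and "the series" means these compounds.

In a functional assay on MDA-MB-231 cells (Homo sapiens) for inhibition, read by CCK-8 assay, with a stated time of 48 h (a higher number here means a weaker inhibitor of growth, a lower number a stronger inhibitor of growth), compound 1 `CN1CCN(c2ccc(Nc3ncc(Cl)c(NCc4ccc(F)cc4)n3)nc2)CC1` gives > 100000 nM, which is a limit of the assay and not a number. Compound 2 `COc1ccc(CNc2nc(Nc3ccc(N4CCN(C)CC4)cn3)ncc2Cl)cc1` gives 14900 nM. For the measured compounds named here, compound 3 `CCc1ccc(Nc2nc(Nc3ccc(N4CCN(C)CC4)cn3)ncc2Cl)cc1` gives 5560 nM, the lowest number so far. Compound 4 `CC(C)c1ccccc1Nc1nc(Nc2ccc(N3CCN(C)CC3)cn2)ncc1Cl` carries 2-isopropylphenyl in place of 4-ethylphenyl on a nitrogen on an aromatic ring. Going by the values given here, no measured step varies this aryl group directly. The nearest guides are a 2.7-fold lower number from compound 2 to compound 3 (0.43 log units; beyond the scatter) and an at least 17-fold lower number from compound 1 to compound 3 (1.25 log units; beyond the scatter), the second resting on a limit. On these data alone, both exchange a substituted benzyl for 4-ethylphenyl, a larger change than the one here, so no step beyond the scatter in this assay is expected, and the direction stays open. The expected step is a 1.1-fold lower number from compound 3 to compound 4 (0.05 log units; within the scatter). For compound 4 the estimate is 5000 nM, with an expected range of 1500 nM to 20000 nM.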

Compound 4, concentration for 50% growth inhibition: 4090 nM
The estimate for compound 4 lay 1.2-fold (0.09 log units) above the measured number; the range from low to high includes it.
By their numbers in this assay, from the lowest: compounds 4 and 3 (each within the scatter of the next); then compound 2. At a limit, above all of these: compound 1.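

In this assay, exchanging the aryl group on this nitrogen gives a 1.4-fold lower number from compound 3 to compound 4 (0.13 log units; within the scatter), so 4-ethylphenyl and 2-isopropylphenyl read alike here. Compared with a substituted benzyl, 2-isopropylphenyl gives a 3.6-fold lower number from compound 2 to compound 4 (0.56 log units; beyond the scatter), which matches the gap already seen for 4-ethylphenyl. The step of an at least 24-fold lower number from compound 1 to compound 4 (1.38 log units; beyond the scatter) rests on a limit and not a number: the limit of > 100000 nM in this assay, at which 1 of the 4 values shown sits.

Still open, on these data alone, is whether an amine or a carboxylic acid on this phenyl ring would change the number beyond the scatter. As far as these compounds go, it is also open whether an unsubstituted phenyl would read like these two groups.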